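This account rests on a few compounds, and the source may have more. Where it says the series, first, only, none or still open, it means among the compounds named here.

Compound 1 `COc1cc2c(cc1N1C[C@@H](C)N(C)[C@@H](C)C1)N(S(=O)(=O)c1ccc3ccccc3c1)CC2`, compound 2 `COc1cc2c(cc1N1CCN[C@@H](C)C1)N(S(=O)(=O)c1ccc(-c3ccccn3)s1)CC2` and compound 3 `COc1cc2c(cc1N1CCN[C@H](C)C1)N(S(=O)(=O)c1ccc(-c3ccccn3)s1)CC2` share a core and have each been measured in a functional assay with growth hormone secretagogue receptor type 1 (Homo sapiens) as the target; on this read-out higher numbers stand for larger maximal responses and lower numbers for smaller maximal responses. In this assay compound 1 gives 0.8, compound 2 gives 1, and compound 3 gives 1. Compound 3 thus stands level with compound 2 at the top of the three numbers, with compound 1 a step lower that lies beyond the usual scatter. Going by the values given here, the only single-point step among the measured compounds runs from compound 2 to compound 3, where no change at the digits printed from compound 2 to compound 3 (within the scatter); this rests on the fact that (the fact that compounds 2 and 3 differ only in the configuration as drawn), so it says little about the change now in question.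

Compound 4 `COc1cc2c(cc1N1C[C@H](C)NC(C)(C)C1)N(S(=O)(=O)c1ccc(-c3ccccn3)s1)CC2` differs from compound 3 as follows: a group of 9 heavy atoms (7 carbon, 2 nitrogen; one six-membered non-aromatic ring with 2 hetero atoms) in place of a group of 7 heavy atoms (5 carbon, 2 nitrogen; one six-membered non-aromatic ring with 2 hetero atoms), on an aromatic carbon. Among the compounds with values here, no measured step involves a change of this kind, so the expectation for compound 4 can lean only on the observation that compound 2 and compound 3 both reach the full response of the reference agonist and that the sole measured variation in this part of the molecule left that response unchanged. Compound 4 is therefore expected to give about 0.95 in this assay, in the range from 0.8 to 1.05, which means an estimated step a number 0.050 lower from compound 3 to compound 4 (within the scatter) from compound 3 to compound 4 of no more than the scatter.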

Compound 4, intrinsic activity: the largest response reached, as a fraction of the reference agonist's: 1
Beside the measured number, compound 4's estimate is 0.050 below it; measured number inside the range.
By their numbers in this assay, from the lowest: compound 1; then compounds 2, 3 and 4 (each within the scatter of the next).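

At this position, on an aromatic carbon ortho to a methoxy group, putting the group of 9 heavy atoms in place of the 3-methylpiperazin-1-yl group gives, in this assay, no change at the digits printed from compound 3 to compound 4 (within the scatter), and the same exchange read from the other starting compound gives no change at the digits printed from compound 2 to compound 4 (within the scatter). The earlier step had tested only a change of drawn configuration at a saturated ring carbon, whereas these steps show that the maximal response also holds when the group itself is enlarged, with its ring type and its counts of hydrogen-bond donors and acceptors staying as they were. The result reads the same from either starting compound, and those two form a closely matched pair: the fact that compounds 2 and 3 differ only in the configuration as drawn.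

The compounds shown leave open whether the maximal response would hold if the ring at this position were replaced by a morpholin-4-yl or piperidin-1-yl group, or by an open-chain amine such as a 2-(dimethylamino)ethylamino group. They also leave open whether a carboxylic acid on the piperazine ring would be accepted here, and this read-out reports only the largest response reached, not the concentration needed to reach it.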